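Methylating the ring nitrogen of compound 3

The source may hold more compounds than are shown below. What is called first, only, known or untested is meant among the compounds shown, and "the series" means these compounds.

Values in a functional assay on PC-3 cells (Homo sapiens) for cytotoxicity, read by MTT assay, with a stated time of 72 h; a lower number here means a stronger inhibitor, a higher number a weaker inhibitor:
- compound 1 `Cc1ccc(-n2nc(C(=O)Nc3ccc(Oc4ncnc5[nH]ccc45)c(F)c3)c(C)cc2=O)cc1`: 20400 nM
- compound 2 `Cc1cc(=O)n(-c2ccccc2OC(F)(F)F)nc1C(=O)Nc1ccc(Oc2ncnc3[nH]ccc23)c(F)c1`: > 60000 nM (a limit of the assay, not a number)
- compound 3 `Cc1cc(=O)n(-c2ccc(Br)cc2F)nc1C(=O)Nc1ccc(Oc2ncnc3[nH]ccc23)c(F)c1`: 13300 nM

Compound 3 has no separate rank among the two true numbers, since the gap is a 1.5-fold lower number from compound 1 to compound 3 (0.19 log units; within the scatter). Against the limit case, the gap is an at least 4.5-fold lower number from compound 2 to compound 3 (0.65 log units; beyond the scatter).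

Compound 4 `Cc1cc(=O)n(-c2ccc(Br)cc2F)nc1C(=O)Nc1ccc(Oc2ncnc3c2ccn3C)c(F)c1` carries one change: methyl in place of hydrogen on an aromatic nitrogen of a five-membered aromatic ring. For the measured compounds named here, no measured step touches that nitrogen. All three steps exchange the phenyl group on a different aromatic nitrogen, and the largest besides the one above is an at least 2.9-fold higher number from compound 1 to compound 2 (0.46 log units; beyond the scatter). Going by the values given here, they show only that single changes can move this assay beyond the scatter, so they give no direction for this one.

The expected outcome is no shift beyond the scatter, with more room allowed towards a higher number. The estimated step is a 1.5-fold higher number from compound 3 to compound 4 (0.18 log units; within the scatter). Compound 4 is estimated at 20000 nM, with an expected range of 7000 nM to 60000 nM.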

Compound 4, half-maximal inhibitory concentration: 6670 nM
For compound 4 the middle estimate is 3.0-fold (0.48 log units) above the measured one, outside the stated range (below it).
By their numbers in this assay, from the lowest: compounds 4, 3 and 1 (each within the scatter of the next, the first and the last beyond it). At a limit, above all of these: compound 2.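

In this assay, placing a methyl in place of hydrogen on the aromatic nitrogen of the five-membered aromatic ring gives a 2.0-fold lower number from compound 3 to compound 4 (0.30 log units; within the scatter). For the compounds shown here, this is the first reading at this position, since all earlier steps exchanged the phenyl group on a different aromatic nitrogen, and it shows that the hydrogen on this nitrogen is not needed to retain the cytotoxicity read here. Nothing given here bears on why this change has the outcome it has.

Only hydrogen and methyl are shown on this nitrogen, so the outcome with an ethyl group, a longer chain, or a chain ending in an amine or a carboxylic acid remains open. The methyl is also shown only with the 4-bromo-2-fluorophenyl group, so its outcome alongside 4-methylphenyl or 2-(trifluoromethoxy)phenyl remains open too.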